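Fluorine Added Next on the Aminochlorophenyl Arm

This account rests on a few compounds, and the source may have more. Where it says the series, first, only, none or still open, it means among the compounds named here.

Of the compounds shown here, two built on a shared core have been measured in a functional assay on BaF3 cells (Mus musculus) for antiproliferative activity, with a stated time of 48 h; a lower number here means a stronger inhibitor, a higher number a weaker inhibitor. Compound 1 `COC(=O)NC12CCC(n3cc(-c4ccc(Cl)c(N)c4)c4c(N)ncnc43)(CC1)CC2` gives 2600 nM in this assay. Compound 2 `CC(=O)N1CCN([C@H]2C[C@@H](n3cc(-c4ccc(Cl)c(N)c4)c4c(N)ncnc43)C2)CC1`, which carries a different group on the core, gives 4600 nM in this assay. Of the two numbers, that of compound 1 is the smaller, but the gap between them lies within the scatter and so carries no ranking.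

Compound 3 `COC(=O)NC12CCC(n3cc(-c4cc(N)c(Cl)cc4F)c4c(N)ncnc43)(CC1)CC2` has not yet been measured. It differs from compound 1 in a single place: fluoro in place of hydrogen on an aromatic carbon. Among the compounds with values here, no measured pair shows this change, so the data offer no direct guide to its effect. The step of a 1.0-fold lower number from compound 1 to compound 3 (0.02 log units; within the scatter) is expected to be small, without a clear direction, and probably not beyond the scatter. Compound 3 is estimated at 2500 nM, with a range from 900 nM to 7000 nM.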

Compound 3, half-maximal inhibitory concentration: 4100 nM
The estimate for compound 3 lay 1.6-fold (0.21 log units) below the measured number, and the stated range covers the measured number.
By their numbers in this assay, from the lowest: compounds 1, 3 and 2 (each within the scatter of the next).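

In this assay, fluoro in place of hydrogen on an aromatic carbon, ortho to a large group and para to an amino group, gives a 1.6-fold higher number from compound 1 to compound 3 (0.20 log units; within the scatter). Within the data shown here, this is the first measured pair to show this change, and it shows that at this place on the arm the added fluoro does not separate the two compounds beyond the scatter, so the 5-amino-4-chloro-2-fluorophenyl arm cannot be ranked against the 3-amino-4-chlorophenyl arm. No measurement is at hand that would explain this result.

As far as these compounds go, whether methyl, methoxy or an amine on the same aromatic carbon would give a step beyond the scatter remains open. So does whether fluoro at this place would give a similar step alongside the different group carried by compound 2.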